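Changing the aromatic group on compound 1

The source may report more compounds than this note shows. Statements on the series, on what has been measured and on what is new or still open speak of the compounds shown alone.

In a functional assay for inhibition, with Sus scrofa as the target (on this read-out higher numbers stand for weaker inhibition and lower numbers for stronger inhibition), compound 1 `CC1(C)Oc2ccc(C#N)cc2[C@@H](n2ccccc2=O)[C@]1(C)O` gives > 100000 nM, which is a limit of the assay and not a number. Compound 3 `CC1=C(N2CCCC2=O)c2cc(C#N)ccc2OC1(C)C` also gives only a limit, > 100000 nM. Together they make up (the limit of > 100000 nM in this assay, at which 2 of the 3 values shown sit). Compound 2 `CC1=C(n2ccccc2=O)c2cc(C#N)ccc2OC1(C)C`, by contrast, gives a measured value of 5000 nM.

Compound 4 `CC1(C)Oc2ccc(C#N)cc2[C@@H](Oc2ccnc(O)c2)[C@]1(C)O` departs from compound 1 at a single place, a saturated ring carbon: a group of 8 heavy atoms (5 carbon, 1 nitrogen, 2 oxygen; one six-membered aromatic ring with 1 hetero atom) in place of a group of 7 heavy atoms (5 carbon, 1 nitrogen, 1 oxygen; one six-membered aromatic ring with 1 hetero atom), on a saturated ring carbon.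

Within the data shown here, only one measured step can be set beside this change: an at least 20-fold higher number from compound 2 to compound 3 (1.30 log units; beyond the scatter). That step is large and beyond the scatter, but it is only an indirect guide. It exchanges a different pair of groups, and on a double-bonded ring carbon rather than a saturated one. It does show that exchanging the group on the core can move the read-out strongly. Compound 2 at 5000 nM also shows that a measurable value is within reach for a compound with a six-membered aromatic group. A move towards a lower number is therefore expected, although the result may well stay at the limit. The expected change is an at least 2.5-fold lower number from compound 1 to compound 4 (0.39 log units; beyond the scatter). Compound 4 is estimated at 40000 nM, with an expected range from 5000 nM to 100000 nM.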

Compound 4, half-maximal inhibitory concentration: 4 nM
Estimate against measurement, compound 4: 10000-fold (4.00 log units) above; measured number outside the range, below it.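

The exchange on the saturated ring carbon gives an at least 25000-fold lower number from compound 1 to compound 4 (4.39 log units; beyond the scatter) and so shows that, in this assay, the group at this one place can decide between no measurable inhibition and very strong inhibition. The earlier compounds shown here showed the core of compound 1, with its hydroxy group, only at a limit, and compound 4 now shows that this core can carry a low measured number, so that core alone does not set the limit. The step is a bound and not an exact size, as one end of it stands at a limit of the assay: (the limit of > 100000 nM in this assay, at which 2 of the 4 values shown sit).

The entering group differs from the leaving one both in how its six-membered aromatic ring is attached to the core and in carrying a hydroxy group, and the compounds shown do not separate these two differences. They also leave open whether an amine or a methoxy group in place of that hydroxy group would keep the number low, and whether the same group would have a comparable effect on the double-bonded core of compound 2.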